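The source may hold more compounds than are shown below. What is called first, only, known or untested is meant among the compounds shown, and "the series" means these compounds.

Working notes on the series.

Compound 1 `CC(C)(C)c1ccc(C(=O)N2CCC3(CC2)C(=O)N(CC(=O)NCCN)CN3c2ccccc2)cc1` is the starting point. In an assay on HEK293 cells for displacement of a labelled ligand from NPC1-like intracellular cholesterol transporter 1 (Homo sapiens) (a lower number here means a stronger inhibitor, a higher number a weaker inhibitor), compound 1 gives 7000 nM, the highest of the three numbers recorded so far. Compound 2 `NCCNC(=O)CN1CN(c2ccccc2)C2(CCN(C(=O)c3ccc(C4CCCCC4)cc3)CC2)C1=O` gives 3800 nM in this assay, and compound 3 `CC1CCCN(C(=O)CN2CN(c3ccccc3)C3(CCN(C(=O)c4ccc(C5CCCCC5)cc4)CC3)C2=O)C1` gives 3600 nM. The step of a 1.8-fold lower number from compound 1 to compound 2 (0.27 log units; within the scatter) and the step of a 1.1-fold lower number from compound 2 to compound 3 (0.02 log units; within the scatter) are both inside the scatter, so the three measured compounds cannot be ordered.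

Compound 4 `CC(C)(C)OC(=O)NCCCNC(=O)CN1CN(c2ccccc2)C2(CCN(C(=O)c3ccc(C(C)(C)C)cc3)CC2)C1=O` has not been measured. It differs from compound 1 by ((tert-butoxycarbonyl)amino)methyl in place of amino on a saturated chain carbon, two bonds along the chain from an amide-type nitrogen. Among the measured compounds shown here, of the two measured steps, only the one from compound 2 to compound 3 touches the same end of the molecule, where the (2-aminoethyl)amino group was exchanged for 3-methylpiperidin-1-yl, and that step stayed within the scatter. The step from compound 1 to compound 2 concerns the aromatic end and does not bear here. With a single relevant step that showed no change, a step of no more than the scatter is expected in this assay for compound 4, in either direction. The expected value for compound 4 is 7000 nM, with a range of 3000 nM to 16000 nM; the step this estimate implies is no change at the digits printed from compound 1 to compound 4 (within the scatter).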

Compound 4, half-maximal inhibitory concentration: 4500 nM
Compound 4: the middle estimate sits 1.6-fold (0.19 log units) above what was measured, and the stated range covers the measured number.
By their numbers in this assay, from the lowest: compounds 3, 2, 4 and 1 (each within the scatter of the next).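

With the tert-butyl group kept on the aromatic end, exchanging amino for ((tert-butoxycarbonyl)amino)methyl on the saturated chain carbon gives a 1.6-fold lower number from compound 1 to compound 4 (0.19 log units; within the scatter) in this assay. Among the compounds shown here, the earlier change at this end of the molecule, (2-aminoethyl)amino to 3-methylpiperidin-1-yl, was seen only with the cyclohexyl group in place, so this result extends the same reading to the tert-butyl compounds: a primary amino end and a tert-butoxycarbonyl-capped chain cannot be told apart here. No supporting data bear on this result.

Going by these compounds, compound 4 changes the chain length and the cap together, so their separate contributions remain open; a (3-aminopropyl)amino group would separate them. A carboxylic acid at the chain end would test a different type of terminal group at this position.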